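This account rests on a few compounds, and the source may have more. Where it says the series, first, only, none or still open, it means among the compounds named here.

Working notes on the dithiocarbamate series in a functional assay on HeLa cells (Homo sapiens) for antiproliferative activity, read by MTT assay, with a stated time of 72 h; on this read-out lower numbers stand for stronger inhibition and higher numbers for weaker inhibition. Compound 1 `CCNC(=S)SCC1=CCOC1=O` is recorded as "not active" (no number reported), with no number reported. Compound 2 `O=C1OCC=C1CSC(=S)NC1CC1` gives 24100 nM in this assay. Compound 3 `CNC(=S)SCC1=CCOC1=O` gives 36100 nM in this assay. Among the measured compounds shown here, the single one-place step measured so far, a 1.5-fold higher number from compound 2 to compound 3 (0.18 log units; within the scatter), places methyl in place of cyclopropyl on the amide-type nitrogen, so compound 3 and compound 2 lie within the scatter of each other, and compound 1 offers no number for comparison. For the measured compounds named here, compound 3 thus stands with compound 2 at the only two numbers available, neither separable from the other.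

Compound 4 `O=C1OCC=C1CSC(=S)NCc1ccccc1` is to be measured in this assay. It differs from compound 3 by phenyl in place of hydrogen on a saturated chain carbon bound to an amide-type nitrogen. Going by the values given here, the only measured step, from compound 2 to compound 3, changes the substituent on the nitrogen itself, not the chain carbon bound to it, and it stayed within the scatter. Among the compounds with values here, no measured step touches the chain carbon, so the phenyl change has no direct precedent here. In the absence of any step beyond the scatter, the expected step from compound 3 to compound 4 is a 1.4-fold lower number from compound 3 to compound 4 (0.16 log units; within the scatter), with a wide range. Compound 4 is therefore estimated at 25000 nM, expected between 7000 nM and 90000 nM.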

Compound 4, half-maximal inhibitory concentration: 15100 nM
For compound 4 the middle estimate is 1.7-fold (0.22 log units) above the measured one; the range from low to high includes it.
By their numbers in this assay, from the lowest: compounds 4, 2 and 3 (each within the scatter of the next, the first and the last beyond it).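

Phenyl in place of hydrogen on a saturated chain carbon bound to an amide-type nitrogen gives a 2.4-fold lower number from compound 3 to compound 4 (0.38 log units; beyond the scatter) in this assay, and this is the first step in the series to lie beyond the scatter, whereas the earlier change on the nitrogen itself, a 1.5-fold higher number from compound 2 to compound 3 (0.18 log units; within the scatter) in the same read-out, stayed within it. The chain carbon bound to the amide-type nitrogen is thus a place where a substituent can shift the number, although the shift here is modest and rests on one pair of compounds. No measurement at hand bears on the origin of this step.

From the compounds shown here alone, compound 1, which carries methyl on the same chain carbon, is recorded as "not active" (no number reported) in place of a number, so the size of the change from hydrogen to methyl there cannot be read, and it remains open whether the shift belongs to phenyl alone or to any group at this carbon. Also open, going by these compounds, is how this place would respond to a pyridine ring, a phenyl ring bearing a methoxy group or a carboxylic acid, or a longer chain between the nitrogen and the ring.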